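Amide aryl variation on the shared core: compound 4

The source may hold more compounds than are shown below. What is called first, only, known or untested is meant among the compounds shown, and "the series" means these compounds.

Measured in a functional assay on MDA-MB-231 cells (Homo sapiens) for cytotoxicity, read by MTT assay, with a stated time of 72 h; on this read-out lower numbers stand for stronger inhibition and higher numbers for weaker inhibition:
compound 1 `O=C(CN1CCN(c2nnc(Cc3ccccc3)c3ccccc23)CC1)Nc1c(F)cccc1F` — 5490 nM
compound 2 `Cc1ccc(NC(=O)CN2CCN(c3nnc(Cc4ccncc4)c4ccccc34)CC2)c(C)c1` — 240 nM
compound 3 `Cc1ccc(F)cc1NC(=O)CN1CCN(c2nnc(Cc3ccccc3)c3ccccc23)CC1` — 19200 nM

Compound 3 gives the highest number of the three; compound 1 sits nearest, compound 2 furthest, both with lower numbers beyond the scatter. Compound 4 `Cc1ccccc1NC(=O)CN1CCN(c2nnc(Cc3ccccc3)c3ccccc23)CC1` is not yet measured. The change from compound 3 is hydrogen in place of fluoro on an aromatic carbon. Within the data shown here, only one measured step concerns the amide-side aryl group: a 3.5-fold higher number from compound 1 to compound 3 (0.54 log units; beyond the scatter), a modest step between two aryl groups that differ in more than one place. Among the measured compounds shown here, compound 2 differs from compound 3 in two places, so its value shows only that another aryl group on the same core can reach a far lower number. For the measured compounds named here, no step shows what removing a single fluoro does. A small shift is expected, more likely toward a lower number, as a 2.1-fold lower number from compound 3 to compound 4 (0.33 log units; beyond the scatter). Compound 4 is therefore estimated at 9000 nM, within 3000 nM to 30000 nM.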

Compound 4, half-maximal inhibitory concentration: 17300 nM
For compound 4 the middle estimate is 1.9-fold (0.28 log units) below the measured one; the range from low to high includes it.
By their numbers in this assay, from the lowest: compound 2; then compound 1; then compounds 4 and 3 (each within the scatter of the next).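

In this assay, hydrogen in place of fluoro on this aromatic carbon, para to a methyl group, gives a 1.1-fold lower number from compound 3 to compound 4 (0.05 log units; within the scatter), so this single fluoro does not separate compound 3 from compound 4. With 2-methylphenyl in place of 2,6-difluorophenyl, the data show a 3.2-fold higher number from compound 1 to compound 4 (0.50 log units; beyond the scatter), so the difference from compound 1 stands with or without this fluoro. No measurement available here bears on the reason for either result.

On these data alone, whether a chloro, a methoxy or an amine on this same carbon would depart from fluoro and hydrogen remains open. So does how much of the value of compound 2, 240 nM, comes from its amide aryl group and how much from its other difference.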